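The source may report more compounds than this note shows. Statements on the series, on what has been measured and on what is new or still open speak of the compounds shown alone.

Three close relatives sharing one core have been tested in a functional assay on SGC-7901 cells (Homo sapiens) for cytotoxicity, read by sulforhodamine B assay, with a stated time of 72 h; on this read-out higher numbers stand for weaker inhibition and lower numbers for stronger inhibition. Compound 2 `C=C1C(=O)O[C@@H]2CC(C)=C([C@@H](C)CCCOC(C)=O)[C@@H](OC(=O)CN3CCCC3)[C@H]12` gives 18400 nM, the highest of the three numbers, though compound 1 `C=C1C(=O)O[C@@H]2CC(C)=C([C@@H](C)CCCOC(C)=O)[C@@H](OC(=O)CN(CC)CC)[C@H]12` with 11600 nM and compound 3 `C=C1C(=O)O[C@@H]2CC(C)=C([C@@H](C)CCCOC(C)=O)[C@@H](OC(=O)c3cccc(F)c3)[C@H]12` with 12900 nM both lie within the scatter of it. Compound 4 `C=C1C(=O)O[C@@H]2CC(C)=C([C@@H](C)CCCOC(C)=O)[C@@H](OC(=O)c3ccc(F)cc3)[C@H]12` has not been measured yet and differs from compound 2 by 4-fluorophenyl in place of (pyrrolidin-1-yl)methyl on a carbonyl carbon. The most relevant measured step is a 1.4-fold lower number from compound 2 to compound 3 (0.15 log units; within the scatter), and a 1.1-fold higher number from compound 1 to compound 3 (0.05 log units; within the scatter) tells the same story for the 3-fluorophenyl group. Both steps stay within the scatter. Compound 4 is expected to follow suit, with a step of a 1.4-fold lower number from compound 2 to compound 4 (0.15 log units; within the scatter) in this assay. The estimate for compound 4 is 13000 nM, with a range from 6000 nM to 28000 nM.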

Compound 4, half-maximal inhibitory concentration: 13600 nM
The estimate for compound 4 lay 1.0-fold (0.02 log units) below the measured number; measured number inside the range.
By their numbers in this assay, from the lowest: compounds 1, 3, 4 and 2 (each within the scatter of the next).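

In this assay, shifting the fluorine from 3-fluorophenyl to 4-fluorophenyl on the carbonyl carbon gives a 1.1-fold higher number from compound 3 to compound 4 (0.02 log units; within the scatter), so these two fluorine placements cannot be told apart. 4-Fluorophenyl also stays level with both amine-bearing groups, with a 1.4-fold lower number from compound 2 to compound 4 (0.13 log units; within the scatter) and a 1.2-fold higher number from compound 1 to compound 4 (0.07 log units; within the scatter), which extends the flat picture at this position to a second aromatic group. No supporting data explain why these groups read alike.

On these data alone, whether a plain phenyl or a (morpholin-4-yl)methyl group on this carbonyl carbon would move the number beyond the scatter remains open.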